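This account rests on a few compounds, and the source may have more. Where it says the series, first, only, none or still open, it means among the compounds named here.

For the measured compounds named here, compound 2 `COc1ccc(Nc2ncnc3cc(OC)c(OCCCCC(=O)Nc4ccc(S(N)(=O)=O)cc4)cc23)cc1` is one of two compounds measured in a functional assay on A-431 cells (Homo sapiens) for antiproliferative activity, read by MTT assay, with a stated time of 72 h (a lower number here means a stronger inhibitor, a higher number a weaker inhibitor), where compound 2 gives 14700 nM, the higher of the two numbers, though its gap to compound 1 lies within the scatter. Compound 1 `COc1cc2ncnc(Nc3cccc(Br)c3)c2cc1OCCCCC(=O)Nc1ccc(S(N)(=O)=O)cc1` in this assay gives 9750 nM; the step of a 1.5-fold higher number from compound 1 to compound 2 (0.18 log units; within the scatter) goes with a 4-methoxyphenyl in place of a 3-bromophenyl on a nitrogen on an aromatic ring. Compound 3 `COc1cc2ncnc(Nc3ccc(C)cc3)c2cc1OCCCCC(=O)Nc1ccc(S(N)(=O)=O)cc1` differs from compound 2 at a single place: methyl in place of methoxy on an aromatic carbon. Going by the values given here, no measured step bears on this exchange of methyl for methoxy; the only step available concerns a different position of the molecule and stayed within the scatter. Nothing in the data points in either direction, so compound 3 is expected to sit close to compound 2 in this assay, with a 1.1-fold lower number from compound 2 to compound 3 (0.02 log units; within the scatter) expected to stay within the scatter. Compound 3 is therefore estimated at 14000 nM, in the range 5000 nM to 40000 nM.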

Compound 3, half-maximal inhibitory concentration: 35500 nM
Beside the measured number, compound 3's estimate is 2.5-fold (0.40 log units) below it, within the range that was stated.
By their numbers in this assay, from the lowest: compounds 1 and 2 (each within the scatter of the next); then compound 3.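

In this assay, methyl in place of methoxy on this aromatic carbon gives a 2.4-fold higher number from compound 2 to compound 3 (0.38 log units; beyond the scatter), so a change at this position, para to a large group, moves the number beyond the scatter, which the earlier exchange of the whole aryl group did not do. Set against compound 1, 4-methylphenyl in place of 3-bromophenyl gives a 3.6-fold higher number from compound 1 to compound 3 (0.56 log units; beyond the scatter), so the identity of the aryl group on the nitrogen can matter in this series, even though compounds 1 and 2 lie within the scatter of each other. Nothing available explains why methyl gives the higher number here. The compounds shown leave open where an ethoxy group, a chlorine or an amine on this same aromatic carbon would fall relative to compound 2 and compound 3. They also leave open whether this step would keep its size with a longer chain on the shared core.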